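This account rests on a few compounds, and the source may have more. Where it says the series, first, only, none or still open, it means among the compounds named here.

Measured compounds:
compound 1 `CC(C)(C)c1ccc(C(=O)N2CCC3(CC2)C(=O)N(CC(=O)NCCC(=O)O)CN3c2ccccc2)cc1` gives 11400 nM in an assay on HEK293 cells for displacement of a labelled ligand from NPC1-like intracellular cholesterol transporter 1 (Homo sapiens); on this read-out lower numbers stand for stronger inhibition and higher numbers for weaker inhibition
compound 2 `O=C(CN1CN(c2ccccc2)C2(CCN(C(=O)c3ccc(C4CCCCC4)cc3)CC2)C1=O)N1CCC(CO)CC1` gives 1100 nM in this assay
compound 3 `CC(C)(C)OC(=O)NCNC(=O)CN1CN(c2ccccc2)C2(CCN(C(=O)c3ccc(C4CCCCC4)cc3)CC2)C1=O` gives 1700 nM in this assay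

Compound 1 shows the highest number of the three in this assay, beyond the scatter from both compound 2 and compound 3. Compound 4 `CC(C)(C)c1ccc(C(=O)N2CCC3(CC2)C(=O)N(CC(=O)NCCN)CN3c2ccccc2)cc1` differs from compound 1 by amino in place of carboxy on a saturated chain carbon, two bonds along the chain from an amide-type nitrogen. Within the data shown here, only one measured step exists, a 1.5-fold higher number from compound 2 to compound 3 (0.19 log units; within the scatter), and it exchanges the whole group on the carbonyl carbon of the amide, not a single terminal group, so it bears only loosely on this change. Compounds 2 and 3 also carry a cyclohexyl rather than a tert-butyl group, so their gap to compound 1 cannot be assigned to the acid alone. On this footing the step from compound 1 to compound 4 is expected to be a 2.9-fold lower number from compound 1 to compound 4 (0.45 log units; beyond the scatter), toward a lower number, and compound 4 is estimated at 4000 nM, between 900 nM and 15000 nM.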

Compound 4, half-maximal inhibitory concentration: 7000 nM
Estimate against measurement, compound 4: 1.8-fold (0.24 log units) below; the range from low to high includes it.
By their numbers in this assay, from the lowest: compounds 2 and 3 (each within the scatter of the next); then compounds 4 and 1 (each within the scatter of the next).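

In this assay the exchange of carboxy for amino on a saturated chain carbon, two bonds along the chain from an amide-type nitrogen, gives a 1.6-fold lower number from compound 1 to compound 4 (0.21 log units; within the scatter) and so this single change at this position, on an otherwise unchanged compound, does not separate the two terminal groups. The carboxy group alone therefore does not set the number of compound 1 apart on this read-out. No supporting measurement bears on this result. On these data alone, whether a hydroxy group, a methyl ester or a longer chain at this place would read differently remains open, as does the effect of cyclohexyl in place of tert-butyl on compound 4.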